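The source may hold more compounds than are shown below. What is called first, only, known or untested is meant among the compounds shown, and "the series" means these compounds.

Compound 1 `CC(=O)N1N=C(c2ccc(C)cc2)CC1c1cn(-c2ccccc2)nc1-c1ccc(Cl)c(Cl)c1` and compound 2 `CC(=O)N1N=C(c2ccc(Cl)cc2)CC1c1cn(-c2ccccc2)nc1-c1ccc(Cl)c(Cl)c1` share one core and differ at a single place. In a functional assay on the whole organism (strain Wistar) for inhibition, with Rattus norvegicus as the target, read by paw edema, with stated times of 30 min and 60 min, at a dose of 50 mg/kg by the oral route (a lower number here means less inhibition, a higher number more inhibition at the dose given (going by the name of the read-out)), compound 1 gives 59.5%, and compound 2 gives 57.3%. Going by the values given here, the one measured step, a number 2.2 percentage points lower from compound 1 to compound 2 (within the scatter), is chloro in place of methyl on an aromatic carbon. On the numbers shown, compound 2 gives the lower of the two, yet the gap lies within the scatter, so the two compounds cannot be told apart. Compound 3 `Clc1ccc(C2=NN(c3ccccc3)C(c3cn(-c4ccccc4)nc3-c3ccc(Cl)c(Cl)c3)C2)cc1` differs from compound 2 by phenyl in place of acetyl on an amine nitrogen in a ring. Among the compounds with values here, no measured pair alters the group on the amine nitrogen in a ring, so nothing measured bears directly on this step; the single step at hand, a number 2.2 percentage points lower from compound 1 to compound 2 (within the scatter), sat elsewhere and stayed within the scatter. For compound 3 the account therefore expects no shift beyond the scatter in this assay, a step of a number 0.3 percentage points lower from compound 2 to compound 3 (within the scatter). Compound 3 is estimated at 57%, between 42% and 70%.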

Compound 3, a percentage reported as inhibition, in the whole organism at one dose (the size of the read-out at that dose, not a potency): 53.4%
For compound 3 the middle estimate is 3.6 percentage points above the measured one; the measured number falls inside the stated range.
By their numbers in this assay, from the lowest: compounds 3, 2 and 1 (each within the scatter of the next).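

The amine nitrogen in a ring, which the earlier pair left unchanged, now has a measured step in this assay: phenyl in place of acetyl gives a number 3.9 percentage points lower from compound 2 to compound 3 (within the scatter). In this one pair, then, the acetyl, with its 1 hydrogen-bond acceptor, can give way to a six-membered aromatic ring of carbon only, with 0 hydrogen-bond acceptors, and the two compounds cannot be told apart at this dose. Nothing available explains this outcome.

From the compounds shown here alone, it remains open whether a free hydrogen, a methyl, a longer acyl chain such as butanoyl or a chain bearing an amine on this nitrogen would move the read-out beyond the scatter. A reading at a single dose also leaves open how compound 2 and compound 3 compare in potency.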